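Replacing 1-benzofuran-2-yl with phenyl on a carbonyl carbon

This account rests on a few compounds, and the source may have more. Where it says the series, first, only, none or still open, it means among the compounds named here.

Measured so far in a functional assay on K562 cells (Homo sapiens) for antiproliferative activity, read by fluorescence, with a stated time of 3 days; a higher number here means a weaker inhibitor, a lower number a stronger inhibitor
Compound 1 `CCCCCSc1nc(OC(=O)CC(C)(C)C)c2cn[nH]c2n1` gives 19800 nM
Compound 2 `CCCCCSc1nc(OC(=O)c2cc3ccccc3o2)c2cn[nH]c2n1` gives 19800 nM
Compound 3 `CCCCCSc1nc(Nc2ccccc2Cl)c2cn[nH]c2n1` gives 19900 nM

Compound 2 stands level with compound 1 and within the scatter of compound 3, so the three show no order. Compound 4 (`CCCCCSc1nc(OC(=O)c2ccccc2)c2cn[nH]c2n1`) differs from compound 2 by phenyl in place of 1-benzofuran-2-yl on a carbonyl carbon and thus carries phenyl in place of 1-benzofuran-2-yl on a carbonyl carbon. Going by the values given here, one measured step bears on this place (no change at the digits printed from compound 1 to compound 2 (within the scatter)) and it replaced neopentyl with 1-benzofuran-2-yl on that carbonyl carbon. Among the compounds with values here, with only that step as a guide, no step beyond the scatter is expected in this assay and no direction can be given. The expected step (a 1.0-fold lower number from compound 2 to compound 4 (0.02 log units; within the scatter)) is estimated to stay within the scatter. For compound 4 the estimated value is 19000 nM with an expected range from 9000 nM to 30000 nM in this assay.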

Compound 4, half-maximal inhibitory concentration: 19800 nM
Compound 4: middle estimate off by 1.0-fold (0.02 log units), on the low side, within the range that was stated.
By their numbers in this assay, from the lowest: compounds 1, 2, 4 and 3 (each within the scatter of the next).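

In this assay phenyl in place of 1-benzofuran-2-yl on the carbonyl carbon gives no change at the digits printed from compound 2 to compound 4 (within the scatter) and phenyl in place of neopentyl gives no change at the digits printed from compound 1 to compound 4 (within the scatter) at the same place. Neopentyl, 1-benzofuran-2-yl and phenyl thus read alike here, so the five-membered aromatic ring of 1-benzofuran-2-yl does not separate compound 2 from compound 4 in this assay. No evidence is available on what lies behind these matching values. On these data alone, whether a carboxylic acid, an amine or a longer chain on this carbonyl carbon would shift the number remains open.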